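Lipophilicity of Two Measured Sulfonamides and an Unmeasured Third

The source may hold more compounds than are shown below. What is called first, only, known or untested is meant among the compounds shown, and "the series" means these compounds.

Compound 1: `CCc1ccc(N(CC2CCC2)S(=O)(=O)c2ccc3c(c2)C(=O)CC(C2CCOCC2)O3)cc1` — 4.1
Compound 2: `CC(C)CN(Cc1ccccc1C(F)(F)F)S(=O)(=O)c1ccc2c(c1)C(=O)CC(C1CCOCC1)O2` — 4.32

For the measured compounds named here, in a physicochemical assay for lipophilicity, at pH 7.4 (a higher number here means a more lipophilic compound, a lower number a more polar compound), compound 2 gives 4.32, the value at the top of the two numbers measured so far. Compound 1 gives 4.1 in this assay, and that number sits within the scatter of compound 2, so the two measured compounds cannot be told apart on this read-out.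

Compound 3 `CC(C)CN(c1ccc(N(C)C)cc1)S(=O)(=O)c1ccc2c(c1)C(=O)CC(C1CCOCC1)O2` differs from compound 2 in one place: 4-(dimethylamino)phenyl in place of 2-(trifluoromethyl)benzyl on a sulfonamide nitrogen. Going by the values given here, no pair of measured compounds differs in this way, so no measured step can be set beside the change; only the two structures and the counted difference are available. Given that the group that enters is smaller by two heavy atoms, carries no fluorine and brings one hydrogen-bond acceptor, a move towards the polar side beyond the usual scatter is expected for compound 3, amounting to a step of a number 0.92 log units lower from compound 2 to compound 3 (beyond the scatter). Compound 3 is therefore estimated at 3.4, with a likely range from 2.9 to 3.9.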

Compound 3, distribution coefficient: 3.6
Beside the measured number, compound 3's estimate is 0.20 log units below it, and the stated range covers the measured number.
By their numbers in this assay, from the lowest: compound 3; then compounds 1 and 2 (each within the scatter of the next).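

In this assay, replacing 2-(trifluoromethyl)benzyl with 4-(dimethylamino)phenyl on a sulfonamide nitrogen gives a number 0.72 log units lower from compound 2 to compound 3 (beyond the scatter). For the compounds shown here, this is the first comparison in which only one place differs, and it shows that the read-out responds to a change at this nitrogen, whereas the earlier values lay within the scatter of each other and came from compounds differing in more than one place. Nothing shown explains the size or direction of this step.

The change swaps fluorine for nitrogen and also alters the group as a whole, so the step cannot be divided among those differences. On these data alone, a plain phenyl group or an unsubstituted benzyl group on this nitrogen would help separate them, and what a carboxylic acid or a longer chain would do there remains open.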